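The source may report more compounds than this note shows. Statements on the series, on what has been measured and on what is new or still open speak of the compounds shown alone.

Measured in an ADME assay on HaCaT cells (Homo sapiens) for cytotoxicity, read by MTT assay, with a stated time of 48 h (a lower number here means a stronger inhibitor, a higher number a weaker inhibitor), all as limits:
compound 1 `Clc1ccc(-c2nn(-c3ccccc3)cc2-c2nc3cc(Cl)ccc3[nH]2)cc1`: > 50000 nM (limit)
compound 2 `Clc1ccc(-c2nn(-c3ccccc3)cc2-c2nc3cc(Br)ccc3[nH]2)cc1`: > 50000 nM (limit)
compound 3 `Clc1ccc(-c2nn(-c3ccccc3)cc2-c2nc3cc(Cl)c(Cl)cc3[nH]2)cc1`: > 50000 nM (limit)

Compound 1 stands only at a limit in this assay, so there is no number from which to count a step. Compound 4 `COc1ccc(-c2nn(-c3ccccc3)cc2-c2nc3cc(Cl)ccc3[nH]2)cc1` has methoxy in place of chloro on an aromatic carbon, the change from 4-chlorophenyl to 4-methoxyphenyl: methoxy in place of chloro on an aromatic carbon.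

Two measured steps are the nearest guide: a step that the two limits leave unreadable from compound 1 to compound 2 and a step that the two limits leave unreadable from compound 1 to compound 3. Neither changes the 4-chlorophenyl group, so they bear on this change only indirectly. Neither has a readable size, because of the limit of > 50000 nM in this assay, at which 3 of the 3 values shown sit. The series therefore gives no direction for this change, and no step beyond the scatter is expected in this assay. A further limit is the likeliest report. The expected step, an estimate only, is a number no higher from compound 1 to compound 4 (the limit leaves the size open). Compound 4 is estimated at 50000 nM, with an expected range of 20000 nM to 100000 nM.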

Compound 4, half-maximal inhibitory concentration: > 50000 nM
Compound 4 was reported as a limit (the forecaster's own chance of this, stated with the estimate: 80%); the middle value sits exactly at the limit.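

No step can be read from compound 1 to compound 4 in this assay, because both are reported only as limits: the limit of > 50000 nM in this assay, at which 4 of the 4 values shown sit.

The compounds shown leave open whether any of these changes alters cytotoxicity, and at what concentration any of the four would reach half-maximal inhibition.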